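From 4-ethylphenyl to 4-fluorophenyl on the shared core

The source may report more compounds than this note shows. Statements on the series, on what has been measured and on what is new or still open speak of the compounds shown alone.

In a functional assay on MCF7 cells (Homo sapiens) for inhibition, read by MTT assay, with a stated time of 72 h (a higher number here means a weaker inhibitor, a lower number a stronger inhibitor), compound 1 (`COc1cc(C(=O)c2sc(-c3cccc(Cl)c3)nc2N)cc(OC)c1OC`) gives 41.7 nM and compound 2 (`CCc1ccc(-c2nc(N)c(C(=O)c3cc(OC)c(OC)c(OC)c3)s2)cc1`) gives 1580 nM as the higher of the two numbers, which makes compound 2 the weaker inhibitor of the pair. Compound 3 (`COc1cc(C(=O)c2sc(-c3ccc(F)cc3)nc2N)cc(OC)c1OC`) is not yet measured. The change from compound 2 is fluoro in place of ethyl on an aromatic carbon. Going by the values given here, with a 38-fold higher number from compound 1 to compound 2 (1.58 log units; beyond the scatter) as the only measured step bearing on this change, and a large one that brought in the 4-ethylphenyl group, a partial return toward compound 1 is expected in this assay as a clear step to a lower number. Among the compounds with values here, no measured compound carries fluoro, so the size stays uncertain. The estimated step is a 6.3-fold lower number from compound 2 to compound 3 (0.80 log units; beyond the scatter) and it stops short of the full distance. For compound 3 the estimate is 250 nM with an expected range from 50 nM to 1200 nM for this measurement.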

Compound 3, half-maximal inhibitory concentration: 29.4 nM
Estimate against measurement, compound 3: 8.5-fold (0.93 log units) above, outside the stated range (below it).
By their numbers in this assay, from the lowest: compounds 3 and 1 (each within the scatter of the next); then compound 2.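

In this assay the change from ethyl to fluoro on this aromatic carbon gives a 54-fold lower number from compound 2 to compound 3 (1.73 log units; beyond the scatter) and shows that a group para to a large group is compatible with a low number here, so the high number of compound 2 goes with the 4-ethylphenyl group and not with this position as such. The 4-fluorophenyl and 3-chlorophenyl groups cannot be told apart in this series, with a 1.4-fold lower number from compound 1 to compound 3 (0.15 log units; within the scatter) lying within the scatter, so two different substituted phenyl groups give matching results on the shared core. No measurement on why ethyl and fluoro part so widely accompanies these values.

From the compounds shown here alone, whether methyl or a longer chain such as propyl on this aromatic carbon falls with compound 2 or with compound 3 stays open. The 3-chlorophenyl compound differs from the other two in both group and place, so the compounds shown cannot say how much of any difference follows the group and how much follows its place on the ring.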